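Swapping a phenyl for a pyridyl on a kinase inhibitor

This account rests on a few compounds, and the source may have more. Where it says the series, first, only, none or still open, it means among the compounds named here.

Among the measured compounds shown here, compound 2 `N#Cc1cnc(NCc2ccccc2C(F)(F)F)cc1N[C@H]1CC[C@@H](C(N)=O)CC1` is the only compound with a plain number in an assay on isolated protein for inhibition of protein kinase C delta type (Homo sapiens), read by TR-FRET, with a stated time of 2 h (a higher number here means a weaker inhibitor, a lower number a stronger inhibitor), where compound 2 gives 640 nM. Compound 1 `CO[C@H]1CC[C@H](Nc2cc(NCc3cnccc3C(F)(F)F)ncc2C#N)CC1` gives > 10000 nM, which is a limit of the assay and not a number. Compound 3 `N#Cc1cnc(NCc2cnccc2C(F)(F)F)cc1N[C@H]1CC[C@@H](C(N)=O)CC1` has not yet been measured; it differs from compound 2 by 4-(trifluoromethyl)pyridin-3-yl in place of 2-(trifluoromethyl)phenyl on a saturated chain carbon bound to a nitrogen on an aromatic ring. Compound 1 carries that same pyridyl group and sits at the limit of > 10000 nM in this assay, at which 1 of the 2 values shown sits. A weakening step from compound 2 to compound 3 of about a 3.9-fold higher number from compound 2 to compound 3 (0.59 log units; beyond the scatter) is expected, with a real chance of another limit. Compound 3 is estimated at 2500 nM, between 600 nM and 10000 nM.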

Compound 3, half-maximal inhibitory concentration: 400 nM
Compound 3: the middle estimate sits 6.3-fold (0.80 log units) above what was measured; the whole stated range lies above it.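

In this assay, 4-(trifluoromethyl)pyridin-3-yl in place of 2-(trifluoromethyl)phenyl gives a 1.6-fold lower number from compound 2 to compound 3 (0.20 log units; within the scatter), so the two groups cannot be told apart at this position. With the pyridyl group held constant, 4-carbamoylcyclohexyl in place of 4-methoxycyclohexyl gives an at least 25-fold lower number from compound 1 to compound 3 (1.39 log units; beyond the scatter), so the pyridyl group alone does not go with the weak result for compound 1. The value of compound 1, > 10000 nM, is a limit of the assay and not a number. Still open, as far as these compounds go, is whether a methyl group in place of trifluoromethyl would hold up on the pyridine, and whether a carboxylic acid or an amine on the cyclohexyl ring could stand in for the carbamoyl group.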